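A side-chain exchange from compound 2 to compound 3

The source may report more compounds than this note shows. Statements on the series, on what has been measured and on what is new or still open speak of the compounds shown alone.

Of the compounds shown here, two have so far been tested in a functional assay on the whole organism with Rattus norvegicus as the target; on this read-out higher numbers stand for an effect only at larger amounts of compound and lower numbers for an effect already at smaller amounts. Compound 1 `Nc1nc2ccc(OCC(F)(F)F)cc2s1` gives 6.5 mg/kg in this assay. Compound 2 `CNS(=O)(=O)CCn1c(=N)sc2cc(OC(F)(F)F)ccc21` gives 4 mg/kg in this assay, a number that lies within the scatter of the number for compound 1, so the two compounds cannot be told apart on these data. Compound 3 `CC[S+]([O-])CCn1c(=N)sc2cc(OC(F)(F)F)ccc21` has not yet been measured. It differs from compound 2 in a single place: a group of 4 heavy atoms (2 carbon, 1 oxygen, 1 sulfur; no ring) in place of a group of 5 heavy atoms (1 carbon, 1 nitrogen, 2 oxygen, 1 sulfur; no ring), on a saturated chain carbon, two bonds along the chain from an aromatic nitrogen. Among the compounds with values here, no pair of measured compounds shows what such an exchange does in this assay, so there is nothing to point to a step beyond the scatter in either direction. Compound 3 is therefore expected to give about 5 mg/kg in this assay, with a likely range from 2 mg/kg to 15 mg/kg. This expectation amounts to an estimated step of a 1.3-fold higher number from compound 2 to compound 3 (0.10 log units; within the scatter).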

Compound 3, dose for half-maximal effect: 1.2 mg/kg
Compound 3: the middle estimate sits 4.2-fold (0.62 log units) above what was measured; measured number outside the range, below it.
By their numbers in this assay, from the lowest: compound 3; then compounds 2 and 1 (each within the scatter of the next).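

In this assay, the saturated chain carbon two bonds along the chain from an aromatic nitrogen proves to be a place where the choice of group matters: replacing methylsulfamoyl with the group of 4 heavy atoms gives a 3.3-fold lower number from compound 2 to compound 3 (0.52 log units; beyond the scatter). This shows that methylsulfamoyl is not needed here for an effect in the whole animal, since the compound without it acts at a smaller dose. The exchange changes the heavy atoms, hydrogen-bond donors, hydrogen-bond acceptors and double bonds all at once, and nothing available explains the step or singles out which of these differences counts.

As far as these compounds go, it remains open how a plain propyl chain, an amine or a carboxylic acid at this place would compare with the group in compound 3. A single step also leaves open whether this exchange would have a similar effect on a different core.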